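Isopropoxy to propargyloxy on compound 3

A few compounds are considered here, and "the series" means these few. Any claim that something is new, unique, unknown or untested is made for them only; others in the source may bear on it.

Of the compounds shown here, three have been measured in a functional assay on the whole organism with Scenedesmus acutus as the target, with a stated time of 20 h; on this read-out higher numbers stand for weaker inhibition and lower numbers for stronger inhibition. Compound 1 `CC(C)Oc1cc(-n2c(=S)n3n(c2=S)CCCC3)c(F)cc1Cl` gives 67.6 nM, and compound 2 `Cc1cc(Cl)ccc1-n1c(=S)n2n(c1=S)CCCC2` gives 85.1 nM. Compound 3 `CC(C)Oc1cc(/N=c2\sc(=S)n3n2CCCC3)c(F)cc1Cl` gives 166 nM. This number lies within the scatter of compound 2 and beyond the scatter on the higher side of compound 1.

Compound 4 `C#CCOc1cc(/N=c2\sc(=S)n3n2CCCC3)c(F)cc1Cl` has propargyl in place of isopropyl on an oxygen on an aromatic ring. For the measured compounds named here, no measured pair shows this exchange, so any expectation is a judgement without a direct precedent. Going by the values given here, the only guide is the narrow spread of the measured values, from compound 1 at 67.6 nM to compound 3 at 166 nM. A small step towards a lower number in this assay is expected, not clearly beyond the scatter. The expected step is a 1.5-fold lower number from compound 3 to compound 4 (0.18 log units; within the scatter). Compound 4 is estimated at 110 nM, with an expected range of 40 nM to 300 nM.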

Compound 4, half-maximal inhibitory concentration: 79.4 nM
Compound 4: the middle estimate sits 1.4-fold (0.14 log units) above what was measured, and the stated range covers the measured number.
By their numbers in this assay, from the lowest: compounds 1, 4, 2 and 3 (each within the scatter of the next, the first and the last beyond it).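

At the oxygen on the aromatic ring, the series now holds its first exchange in a single place: in this assay, propargyl in place of isopropyl gives a 2.1-fold lower number from compound 3 to compound 4 (0.32 log units; beyond the scatter). The read-out therefore responds to the group at this position, even though the two groups have the same heavy-atom count and the same lack of hydrogen-bond donors and acceptors, and the entering group adds a triple bond outside aromatic rings. Nothing at hand bears on what lies behind this step.

The compounds shown leave open whether the same exchange gives a comparable step on the core of compound 1, since it is shown only on the core of compound 3. Also open, as far as these compounds go, is how this position reads with a longer chain such as butyl, or with a carboxylic acid on the chain.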